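Aryl replacement on the shared core: maximal response notes

The compounds below may be only part of what the source reports. "The series", "measured", "known", "first", "only" and "open" are said of these compounds alone.

Values from an in vitro functional assay on HEK285-7 cells for antagonist activity at prostaglandin D2 receptor 2 (Homo sapiens), read by BRET and beta-arrestin recruitment (on this read-out higher numbers stand for larger maximal responses and lower numbers for smaller maximal responses), for the three measured compounds:
compound 1 `NS(=O)(=O)c1ccc(-c2nc(C(c3ccc(F)cc3)c3ccc(F)cc3)sc2CC(=O)O)cc1` gives 80%
compound 2 `O=C(O)Cc1sc(C(c2ccc(F)cc2)c2ccc(F)cc2)nc1-c1ccoc1` gives 80%
compound 3 `O=C(O)Cc1sc(C(c2ccc(F)cc2)c2ccc(F)cc2)nc1-c1ccnc(N2CCC2)c1` gives 80%

Compound 3 stands level with compounds 1 and 2 at the digits shown; nearest is compound 1, furthest compound 2, both within the scatter. The three measured steps all concern the group on an aromatic carbon of the shared core, and none moved the read-out: no change at the digits printed from compound 1 to compound 2 (within the scatter), no change at the digits printed from compound 1 to compound 3 (within the scatter), no change at the digits printed from compound 2 to compound 3 (within the scatter).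

Compound 4 `N#Cc1cc(-c2nc(C(c3ccc(F)cc3)c3ccc(F)cc3)sc2CC(=O)O)ccc1F` is a further exchange at the same carbon. Its difference from compound 3: 3-cyano-4-fluorophenyl in place of 2-(azetidin-1-yl)pyridin-4-yl on an aromatic carbon. The six-membered aromatic ring with 1 hetero atom carrying a four-membered non-aromatic ring gives way to a six-membered aromatic ring of carbon only carrying a nitrile and a fluorine.

All three measured steps bear on this change, since each swapped the whole group at that carbon among quite different aromatic rings, and each stayed within the scatter. The maximal response in this assay is therefore expected to remain where the measured compounds sit, and the step of no change at the digits printed from compound 3 to compound 4 (within the scatter) is estimated to be none beyond the scatter. For compound 4 the expected value in this assay is 80%, with a range from 66% to 92%. This rests on three compounds only, a narrow base.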

Compound 4, largest response reached (reported as efficacy), in percent of the reference or control that the assay uses: 80%
Beside the measured number, compound 4's estimate shows no gap at the digits printed; measured number inside the range.
By their numbers in this assay, from the lowest: compounds 1, 2, 3 and 4 (each within the scatter of the next).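

Working notes on the aryl position: in this assay the exchange for 3-cyano-4-fluorophenyl gives no change at the digits printed from compound 3 to compound 4 (within the scatter) and, against the two other groups, no change at the digits printed from compound 2 to compound 4 (within the scatter) and no change at the digits printed from compound 1 to compound 4 (within the scatter) on the same aromatic carbon next to the ring nitrogen. The new information is that a ring of carbon only carrying a nitrile and a fluorine fits the same picture as the sulfamoylphenyl, furanyl and azetidinylpyridinyl groups, so all four groups at this carbon now sit within the scatter of one another and none of the shown compounds goes against this flatness. Nothing available here explains why the maximal response holds across these exchanges.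

Still open, from the compounds shown here alone, is whether a non-aromatic group at this carbon, such as a piperidine, a morpholine or a plain methyl, would leave the maximal response where the four aromatic groups hold it. Also open, going by these compounds, is whether the flat picture survives a change elsewhere on the shared core, for instance an amide or a longer chain ending in a carboxylic acid in place of the carboxymethyl group.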